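The source may report more compounds than this note shows. Statements on the series, on what has been measured and on what is new or still open speak of the compounds shown alone.

Within the data shown here, compound 1 `c1ccc(-c2cc(-c3cccs3)cc(-c3ccco3)n2)cc1` is one of two compounds measured so far in a functional assay on HCT-15 cells (Homo sapiens) for antiproliferative activity (a higher number here means that more compound is needed for the effect, a lower number that less compound is needed), where compound 1 gives 118000 nM. The other is compound 2 `c1csc(-c2cc(-c3cccs3)nc(-c3cccs3)c2)c1`, which in this assay gives 118000 nM. At the digits reported, compound 1 stands level with compound 2, and the two values lie within the usual scatter of each other, so neither can be called the more or less potent of the pair.

Compound 3 `c1coc(-c2cc(-c3cccs3)cc(-c3ccco3)n2)c1` has not been measured yet. It arises from compound 1 by a single change, (furan-2-yl in place of phenyl on an aromatic carbon), so that the shared core now carries two furan-2-yl groups together with the thiophen-2-yl group.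

Among the measured compounds shown here, no step between two measured compounds that differ in one place is available to guide the expectation. What is known is that compound 1 and compound 2, which differ in the kind of five- and six-membered aromatic rings attached to the shared core, give values that agree within the scatter. For the measured compounds named here, on that basis compound 3 is expected to show no step in this assay beyond the scatter, with no change at the digits printed from compound 1 to compound 3 (within the scatter) as the anticipated change. The estimate for compound 3 is therefore 118000 nM, with a range from 50000 nM to 280000 nM.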

Compound 3, half-maximal effective concentration: 118000 nM
Estimate against measurement, compound 3: no gap at the digits printed; the measured number falls inside the stated range.
By their numbers in this assay, from the lowest: compounds 1, 2 and 3 (each within the scatter of the next).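

Among these compounds, with furan-2-yl in place of phenyl on the aromatic carbon next to the ring nitrogen, this assay gives no change at the digits printed from compound 1 to compound 3 (within the scatter) as the first step that can be read at a single place. At this position, therefore, a five-membered aromatic ring with 1 hetero atom, bringing a hydrogen-bond acceptor, takes the place of a six-membered aromatic ring of carbon only with no step beyond the scatter in this read-out. No independent evidence bears on why the two groups give this result.

The compounds shown carry only aromatic rings at this position, so it remains open whether an amine, a carboxylic acid or a longer chain placed there would give a step beyond the scatter. On these data alone, it is also open whether the thiophen-2-yl group or the other furan-2-yl group of compound 3 would show a step of its own if replaced by one of these groups, since no single-place change at either of those two positions is available here.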